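The source may hold more compounds than are shown below. What is called first, only, known or untested is meant among the compounds shown, and "the series" means these compounds.

Of the compounds shown here, three built on one shared core have so far been tested in an assay on membranes from brain (Cavia porcellus) for binding affinity to Sigma non-opioid intracellular receptor 1 (Homo sapiens); on this read-out higher numbers stand for weaker inhibition and lower numbers for stronger inhibition. Compound 1, `Cc1ccccc1/N=C(/N)Nc1ccccc1I`, gives 23 nM. Compound 2, `Cc1ccccc1/N=C(\N)NC1CCCCC1`, gives 15 nM in this assay, and compound 3, `Cc1ccccc1/N=C(/N)Nc1ccc([N+](=O)[O-])cc1C`, gives 39 nM. Of these three numbers, compound 1 holds the second highest; its nearest neighbour is compound 2 and its furthest is compound 3, yet both gaps lie within the usual scatter of repeated measurements, so none of the three can be placed above or below another.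

The next compound, compound 4, `Cc1ccccc1/N=C(/N)Nc1ccccc1N`, differs from compound 1 in a single place: amino in place of iodo on an aromatic carbon. Among the compounds with values here, no two measured compounds differ in only one place, so no measured step offers a direct guide to what this exchange does. The three measured values sit in a narrow band, and the exchange itself is small in atom count, so the expectation is a modest move toward a higher number, a weaker inhibition, that may or may not exceed the scatter; the expected step from compound 1 to compound 4 is a 2.6-fold higher number from compound 1 to compound 4 (0.42 log units; beyond the scatter). Compound 4 is therefore expected to give about 60 nM in this assay, with a likely range from 20 nM to 200 nM.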

Compound 4, half-maximal inhibitory concentration: 440 nM
Compound 4: the middle estimate sits 7.3-fold (0.87 log units) below what was measured; measured number outside the range, above it.
By their numbers in this assay, from the lowest: compounds 2, 1 and 3 (each within the scatter of the next, the first and the last beyond it); then compound 4.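

Within the data shown here, this is the first single exchange on the shared core that can be read, and in this assay it turns out large: amino in place of iodo on an aromatic carbon, ortho to a large group, brings a 19-fold higher number from compound 1 to compound 4 (1.28 log units; beyond the scatter). The position is therefore far from indifferent to what it carries, even though one heavy atom simply replaces another, and the entering amino counts one hydrogen-bond donor and one hydrogen-bond acceptor where iodo counts none. Nothing at hand shows which difference between the two groups lies behind a step of this size.

Still open, going by these compounds, is whether the step follows from the arrival of the amino or from the departure of the iodo, as one exchange cannot separate the two. Also unknown is where a chloro, a methoxy or a hydroxyl on the same aromatic carbon would fall relative to compound 1 and compound 4, which would show whether iodo is unusually favourable here or amino unusually poor.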